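Compound 4: a larger group on the ring nitrogen

The compounds below may be only part of what the source reports. "The series", "measured", "known", "first", "only" and "open" are said of these compounds alone.

Measured in an ADME assay on L02 cells (Homo sapiens) for cytotoxicity, read by MTT assay, with a stated time of 72 h; on this read-out higher numbers stand for weaker inhibition and lower numbers for stronger inhibition:
- compound 1 `COc1ccc(/C=C2\CNC/C(=C\c3ccc(OC)c(OC)c3)C2=O)cc1OC`: 15100 nM
- compound 2 `COc1cc(/C=C2\CNC/C(=C\c3cc(OC)c(OC)c(OC)c3)C2=O)cc(OC)c1OC`: 7600 nM
- compound 3 `CCN1C/C(=C\c2ccc(OC)c(OC)c2)C(=O)/C(=C/c2ccc(OC)c(OC)c2)C1`: 9800 nM

Compound 2, at 7600 nM, lies within the scatter of both compound 1 and compound 3. Compound 4 `COc1cc(/C=C2\CN(C(=O)CCC(=O)O)C/C(=C\c3cc(OC)c(OC)c(OC)c3)C2=O)cc(OC)c1OC` differs from compound 2 by (2-carboxyethyl)carbonyl in place of hydrogen on an amine nitrogen in a ring. Going by the values given here, one measured step bears on this, ethyl in place of hydrogen at that nitrogen, and it shows a 1.5-fold lower number from compound 1 to compound 3 (0.19 log units; within the scatter). Among the compounds with values here, no measured compound carries the new group, so this guide is weak. In this assay, no shift beyond the scatter is therefore expected, and the expected change is a 1.2-fold higher number from compound 2 to compound 4 (0.07 log units; within the scatter). Compound 4 is estimated at 9000 nM, with an expected range of 3000 nM to 30000 nM.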

Compound 4, half-maximal inhibitory concentration: > 60000 nM
Compound 4 was reported as a limit (the forecaster's own chance of this, stated with the estimate: 5%); middle value at least 6.6-fold (0.82 log units) away from the limit.
By their numbers in this assay, from the lowest: compounds 2, 3 and 1 (each within the scatter of the next). At a limit, above all of these: compound 4.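

In this assay there is an at least 7.8-fold higher number from compound 2 to compound 4 (0.89 log units; beyond the scatter), which shows that a change on this amine nitrogen can move the number beyond the scatter. Going by these compounds alone, the only earlier step at this nitrogen, a 1.5-fold lower number from compound 1 to compound 3 (0.19 log units; within the scatter), did not show this, and it was made on the core of compound 1 rather than that of compound 2. The value for compound 4 is a limit, so the full size of its step is unknown: the limit of > 60000 nM in this assay, at which 1 of the 4 values shown sits.

The compounds shown do not separate the part played by the carboxylic acid from that of the carbonyl on the nitrogen. An acetyl group or the methyl ester of the same chain would bear on this.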